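Replacing 3-aminophenyl with 2-methylphenyl in the series

The source may hold more compounds than are shown below. What is called first, only, known or untested is meant among the compounds shown, and "the series" means these compounds.

- compound 1 `Fc1ccc(Nc2nc(-c3cccc(F)c3)nc3ccc(F)cc23)cc1` in a functional assay on MDA-MB-231 cells (Homo sapiens) for cytotoxicity, read by MTT assay, with a stated time of 48 h (on this read-out higher numbers stand for weaker inhibition and lower numbers for stronger inhibition), gives > 50000 nM as a limit
- compound 2 `Nc1cccc(Nc2nc(-c3cccc(F)c3)nc3ccc(F)cc23)c1` in this assay gives > 50000 nM as a limit

Compound 2 has no numerical value in this assay and stands only at its limit. Among the compounds with values here, the one other value, that of compound 1, is also a limit, so compound 2 cannot be ranked against it.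

Compound 3 `Cc1ccccc1Nc1nc(-c2cccc(F)c2)nc2ccc(F)cc12` has 2-methylphenyl in place of 3-aminophenyl on a nitrogen on an aromatic ring and is otherwise unchanged. Within the data shown here, the only measured step that bears on this change is a step that the two limits leave unreadable from compound 1 to compound 2 and it concerns the same place on the shared core, but it offers no size to carry over.

No step beyond the scatter is expected in either direction because the limit of > 50000 nM in this assay, at which 2 of the 2 values shown sit, gives no sign of a change at this place. The expected change is a number no higher from compound 2 to compound 3 (the limit leaves the size open) and no larger shift is foreseen. Compound 3 is estimated at 50000 nM within an expected range of 20000 nM to 100000 nM and is expected more likely than not to stand only at a limit.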

Compound 3, half-maximal inhibitory concentration: > 50000 nM
Compound 3 gave a limit, no number; the forecaster's own chance of this, stated with the estimate: 75%; the middle value lies on the limit itself.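

Compound 1, compound 2 and compound 3 all stand only at a limit in this assay, so no step among them can be read: the limit of > 50000 nM in this assay, at which 3 of the 3 values shown sit.

The compounds shown leave open whether any group at this place on the shared core gives a measurable number in this assay, and how large a step between such groups would be.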